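Methoxy to Chloro on the Aryl Ring of a Shared Core

This account rests on a few compounds, and the source may have more. Where it says the series, first, only, none or still open, it means among the compounds named here.

Compound 1, `O=S(=O)(c1cc(Cl)cc(Cl)c1)c1cnc2cc(F)ccc2c1-c1ccccc1F`: 0.93 mL/min
Compound 2, `O=S(=O)(c1cc(F)cc(F)c1)c1cnc2cc(F)ccc2c1-c1cccc(Cl)c1`: 0.22 mL/min
Compound 3, `COc1cccc(-c2c(S(=O)(=O)c3cc(Cl)cc(Cl)c3)cnc3cc(F)ccc23)c1`: 1.51 mL/min

Of the compounds shown here, three have been measured in an ADME assay on microsomes from liver (Homo sapiens) for metabolic stability, tested at 2.5 uM; a lower number here means slower removal, a higher number faster removal of the compound. Compound 3 gives the highest of the three numbers; compound 1 is nearest to it, lower by an amount that is within the usual scatter, while compound 2 is furthest, lower by an amount that lies beyond the scatter. Going by the values given here, the only step between measured compounds that differ in one place is a 1.6-fold higher number from compound 1 to compound 3 (0.21 log units; within the scatter), and it is within the scatter.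

Compound 4, `O=S(=O)(c1cc(Cl)cc(Cl)c1)c1cnc2cc(F)ccc2c1-c1cccc(Cl)c1`, is not yet measured. It differs from compound 3 in one place: chloro in place of methoxy on an aromatic carbon. Among the compounds with values here, no measured step exchanges methoxy for chloro, so nothing bears directly on this change; the one step at this position of the ring, from compound 1 to compound 3, stayed within the scatter. Within the data shown here, compound 2 carries the same 3-chlorophenyl as compound 4 but a different sulfonyl aryl group, and its value is far below that of compound 3, yet no single-point step links it to compound 4.

The step is therefore expected to stay within the scatter, a 1.5-fold lower number from compound 3 to compound 4 (0.18 log units; within the scatter). For compound 4 the estimate is 1 mL/min, in the range 0.4 mL/min to 2.5 mL/min.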

Compound 4, intrinsic clearance in a liver preparation (reported as CLH), per the amount of preparation that the assay uses: 0.93 mL/min
Compound 4: middle estimate off by 1.1-fold (0.03 log units), on the high side, and the stated range covers the measured number.
By their numbers in this assay, from the lowest: compound 2; then compounds 1, 4 and 3 (each within the scatter of the next).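

In this assay the exchange of methoxy for chloro on this aromatic carbon makes little difference, with a 1.6-fold lower number from compound 3 to compound 4 (0.21 log units; within the scatter) and so no reading of order between 3-methoxyphenyl and 3-chlorophenyl. With the 3,5-dichlorophenyl on the sulfonyl sulfur held fixed, 3-chlorophenyl and 2-fluorophenyl also read alike, showing no change at the digits printed from compound 1 to compound 4 (within the scatter) as the step between them, so all three aryl groups tried at this place stay within the scatter of each other. Going by these compounds alone, the one single-place step beyond the scatter lies at the other aryl group, where 3,5-dichlorophenyl in place of 3,5-difluorophenyl on the sulfonyl sulfur gives a 4.2-fold higher number from compound 2 to compound 4 (0.63 log units; beyond the scatter) with the 3-chlorophenyl unchanged, which places the low number of compound 2 with its sulfonyl aryl group rather than with its 3-chlorophenyl. Nothing shown here gives a reason for the size of any of these steps.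

On these data alone, it remains open whether a quite different group on this aromatic carbon, such as an amine or a carboxylic acid, would move the number beyond the scatter. As far as these compounds go, it is also open whether the step between 3,5-difluorophenyl and 3,5-dichlorophenyl keeps its size when 2-fluorophenyl or 3-methoxyphenyl takes the place of 3-chlorophenyl.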